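Adding a methoxy group: what to expect for compound 3

The source may report more compounds than this note shows. Statements on the series, on what has been measured and on what is new or still open speak of the compounds shown alone.

Measured so far in an ADME assay on RAW264.7 cells (Mus musculus) for cytotoxicity, read by MTT assay, with a stated time of 24 h, tested at 5 ug/mL; on this read-out higher numbers stand for a weaker effect at the one concentration tested and lower numbers for a stronger effect:
compound 1 `COc1ccc(C(=O)CCc2ccc(OC)c(OC)c2)c(O)c1`: 75.2%
compound 2 `COc1cc(C(=O)CCc2cccc(OC)c2OC)ccc1O`: 91.1%

Of these two numbers, compound 1 stands at the lower one, which on this read-out is the stronger effect on the cells. Its nearest neighbour, compound 2, lies higher by a gap that is beyond the usual scatter, so the two compounds do differ in this assay. Compound 2 is built on a different core, so it gives no guide to what a single change on the core of compound 1 does.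

Compound 3 `COc1ccc(C(=O)CCc2ccc(OC)c(OC)c2OC)c(O)c1` has not yet been measured. It differs from compound 1 in one place:
methoxy in place of hydrogen on an aromatic carbon

Among the compounds with values here, no measured pair shows what this change does in this assay, so nothing in the data points to a large move in either direction. The expected step is small, likely within the scatter, and is written as a number 2.8 percentage points higher from compound 1 to compound 3 (within the scatter). Compound 3 is therefore estimated at 78%, with a range from 60% to 95%.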

Compound 3, a percentage reported as activity, at one concentration (the size of the read-out at that concentration, not a potency): 94.8%
Estimate against measurement, compound 3: 16.8 percentage points below, and the stated range covers the measured number.
By their numbers in this assay, from the lowest: compound 1; then compounds 2 and 3 (each within the scatter of the next).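

In this assay a methoxy group on the aromatic carbon that is ortho to a large group, ortho to a methoxy group and meta to a methoxy group gives a number 19.6 percentage points higher from compound 1 to compound 3 (beyond the scatter). This is a weaker effect on the cells, and the step lies beyond the usual scatter. Within the data shown here, this pair differs in one place only, so it gives the first direct reading of what a single change on the core of compound 1 does, and it shows that this position is not indifferent to substitution: replacing one hydrogen atom with a group of just two heavy atoms is enough to produce a real shift. The data give the direction and size of this step, but no separate measurement is on hand to explain it.

One pair cannot show whether this shift is particular to methoxy or would appear with other groups on the same carbon, such as an ethoxy group, an amine or a carboxylic acid. It also leaves open whether methoxy would produce a step of similar size on another aromatic carbon of the shared core.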